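The compounds below may be only part of what the source reports. "The series", "measured", "known", "first", "only" and "open" are said of these compounds alone.

Measured so far:
compound 1, `CC[C@@H](Nc1c(C#N)c(-c2ccc(-c3ccccc3C(F)(F)F)cc2)nc2cnccc12)C(N)=O`: 3.1
compound 2, `CC[C@@H](Nc1c(C#N)c(-c2ccc(-c3ccccc3N(C)C)cc2)nc2cnccc12)C(N)=O`: 3.2
compound 3, `CC[C@@H](Nc1c(C#N)c(-c2ccc(-c3cccc(Cl)c3)cc2)nc2cnccc12)C(N)=O`: 3.1

In a physicochemical assay for lipophilicity, read by HPLC, at pH 7.5 (on this read-out higher numbers stand for higher lipophilicity and lower numbers for lower lipophilicity), compound 3 gives 3.1. It stands level with compound 1, the two together forming the lowest pair of the three numbers, and its nearest neighbour is compound 1, no change at the digits printed from compound 1 to compound 3 (within the scatter); its furthest is compound 2, a number 0.10 log units lower from compound 2 to compound 3 (within the scatter). Every step among the measured compounds changes the outer aryl ring at the same place, and none of them moves beyond the scatter.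

Compound 4, `CC[C@@H](Nc1c(C#N)c(-c2ccc(-c3ccc(OC)cc3)cc2)nc2cnccc12)C(N)=O`, is not yet measured. It differs from compound 3 as follows: 4-methoxyphenyl in place of 3-chlorophenyl on an aromatic carbon. Among the compounds with values here, the steps that bear on this are those between compounds 1, 2 and 3, a number 0.10 log units higher from compound 1 to compound 2 (within the scatter) and no change at the digits printed from compound 1 to compound 3 (within the scatter), all small. Within the data shown here, no measured step exchanges a chlorine for a methoxy group, so the direction is uncertain; the account expects compound 4 to show at most a small step, a number 0.20 log units lower from compound 3 to compound 4 (within the scatter), with no change beyond the scatter. Compound 4 is therefore estimated at 2.9, between 2.5 and 3.3.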

Compound 4, distribution coefficient: 2.7
Compound 4: middle estimate off by 0.20 log units, on the high side, within the range that was stated.
By their numbers in this assay, from the lowest: compound 4; then compounds 1, 3 and 2 (each within the scatter of the next).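

In this assay, within the data shown here, the outer aryl ring at this position is not indifferent to exchange: the earlier compounds all lay within the scatter of one another, whereas 4-methoxyphenyl in place of 3-chlorophenyl gives a number 0.40 log units lower from compound 3 to compound 4 (beyond the scatter). Against the other two rings the same group gives a number 0.50 log units lower from compound 2 to compound 4 (beyond the scatter) and a number 0.40 log units lower from compound 1 to compound 4 (beyond the scatter), which makes compound 4 the lowest of the four on this read-out. Among these compounds, the entering group also carries a hydrogen-bond acceptor, which none of the leaving 3-chlorophenyl's atoms is counted as, and it is the only one of the four rings with this substitution.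

Nothing available gives a reason for this step. From the compounds shown here alone, whether the methoxy group itself or its place on the ring accounts for the step stays open, as does how a 4-chlorophenyl ring, or an outer ring bearing a carboxylic acid, would read.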